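Replacing 3-oxopiperazin-1-yl with 2-ethoxyethoxy in a cell tolerance test

A few compounds are considered here, and "the series" means these few. Any claim that something is new, unique, unknown or untested is made for them only; others in the source may bear on it.

Of the compounds shown here, two built on a shared core have been measured in an ADME assay on CEM-SS cells (Homo sapiens) for cytotoxicity, read by XTT assay; a lower number here means that less compound is tolerated, a higher number that more compound is tolerated. In this assay compound 1 (`CN(O)C(=O)c1cc2ccn(Cc3ccc(F)cc3F)c2cn1`) gives 200000 nM. Compound 2 (`CN(O)C(=O)c1cc2c(CN3CCNC(=O)C3)cn(Cc3ccc(F)cc3)c2cn1`) gives > 100000 nM, which is a limit of the assay and not a number. Compound 2 can therefore be placed only by that limit, and the record shows (the limit of > 100000 nM in this assay, at which 1 of the 2 values shown sits).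

Compound 3 (`CCOCCOCc1cn(Cc2ccc(F)cc2)c2cnc(C(=O)N(C)O)cc12`) has 2-ethoxyethoxy in place of 3-oxopiperazin-1-yl on a saturated chain carbon bound to an aromatic carbon, a difference that counts as 2-ethoxyethoxy in place of 3-oxopiperazin-1-yl on a saturated chain carbon bound to an aromatic carbon. Among the compounds with values here, no measured pair of compounds shows what this replacement does. The expectation therefore rests on the two high readings, including compound 1 at 200000 nM, which carries neither of these groups. No change beyond the usual scatter is expected, and the estimated step is a number no higher from compound 2 to compound 3 (the limit leaves the size open). In this assay, compound 3 is estimated at 100000 nM, with an expected range from 30000 nM to 300000 nM.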

Compound 3, half-maximal cytotoxic concentration: 81000 nM
For compound 3 the middle estimate is 1.2-fold (0.09 log units) above the measured one; low and high end bracket the measured number.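

In this assay, within the data shown here, compound 3 gives 81000 nM, and this is the first reading with a group on a saturated chain carbon bound to an aromatic carbon that is a number rather than a limit. Putting 2-ethoxyethoxy, which has no ring and no hydrogen-bond donor, in place of 3-oxopiperazin-1-yl gives an at least 1.2-fold lower number from compound 2 to compound 3 (0.09 log units; that floor lies within the scatter), so only the smallest possible size of this change is known, and that smallest size does not go beyond the usual scatter. The full size of the step cannot be given because compound 2 is recorded only as a limit: the limit of > 100000 nM in this assay, at which 1 of the 3 values shown sits.

The compounds shown leave open whether this replacement has any real effect on cell tolerance, since the reading for compound 2 has no upper end. They also leave open how a simple amine, a carboxylic acid or a chain longer than 2-ethoxyethoxy would read on the same saturated chain carbon.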